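The source may hold more compounds than are shown below. What is called first, only, known or untested is meant among the compounds shown, and "the series" means these compounds.

In a functional assay on MCF7 cells (Homo sapiens) for cytotoxicity, read by MTT assay, with a stated time of 48 h (on this read-out higher numbers stand for weaker inhibition and lower numbers for stronger inhibition), compound 1 `C/C(=N\NC(=S)Nc1ccccc1)c1ccccn1` gives 0.18 nM, compound 2 `C/C(=N/NC(=S)Nc1ccc(I)cc1)c1ccccn1` gives 6.61 nM, and compound 3 `C/C(=N\NC(=S)Nc1ccc(I)cc1)c1ccccn1` gives 6.61 nM. Compound 3 stands level with compound 2, the two together the highest of the three numbers, and furthest from compound 1. The measured steps: a 37-fold higher number from compound 1 to compound 3 (1.56 log units; beyond the scatter); and no change at the digits printed from compound 2 to compound 3 (within the scatter), which is read against (the fact that compounds 2 and 3 differ only in the configuration as drawn). Compound 4 `C/C(=N\NC(=S)Nc1ccc([N+](=O)[O-])cc1)c1ccccn1` differs from compound 3 by nitro in place of iodo on an aromatic carbon. Within the data shown here, no measured step swaps one group for another on that aromatic carbon; the step from compound 1 to compound 3 shows only that placing a group there moves the number, and by a large amount. The step from compound 3 to compound 4 is therefore expected to be modest, a 1.3-fold lower number from compound 3 to compound 4 (0.12 log units; within the scatter), in either direction. Compound 4 is estimated at 5 nM, within 1 nM to 25 nM.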

Compound 4, half-maximal inhibitory concentration: 52 nM
Beside the measured number, compound 4's estimate is 10-fold (1.02 log units) below it; measured number above the stated range.
By their numbers in this assay, from the lowest: compound 1; then compounds 2 and 3 (each within the scatter of the next); then compound 4.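

Swapping one group for another on this aromatic carbon, para to a large group, moves the number, so the identity of the group counts and not only its presence: nitro in place of iodo gives a 7.9-fold higher number from compound 3 to compound 4 (0.90 log units; beyond the scatter) in this series. Nitro in place of hydrogen gives a 290-fold higher number from compound 1 to compound 4 (2.46 log units; beyond the scatter) and is the largest step shown at this position. Nothing available bears on why nitro and iodo part here.

From the compounds shown here alone, whether an amine or a methoxy group on this carbon would come back towards compound 1 stays open. So does whether the configuration of the double bond stays without visible effect with nitro, as it does with iodo.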